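Swapping a chlorophenyl group for a ringless group

The source may report more compounds than this note shows. Statements on the series, on what has been measured and on what is new or still open speak of the compounds shown alone.

Compound 1 `O=[N+]([O-])c1ccc2[nH]c(CSCc3nc4cc([N+](=O)[O-])ccc4[nH]3)nc2c1`: 1740 nM
Compound 2 `O=C(CSCc1nc2cc([N+](=O)[O-])ccc2[nH]1)c1ccc(Cl)cc1`: 2800 nM
Compound 3 `N#CCSCc1nc2cc([N+](=O)[O-])ccc2[nH]1`: 27400 nM

All three compounds were tested in a functional assay on MCF7 cells (Homo sapiens) for cytotoxicity, read by MTT assay, with a stated time of 48 h; on this read-out higher numbers stand for weaker inhibition and lower numbers for stronger inhibition. Compound 2 gives 2800 nM and sits within the scatter of compound 1 (1740 nM), so these two cannot be ranked. Compound 3 (27400 nM) gives a higher number than compound 2, and that gap lies beyond the scatter.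

Compound 4 `NC(=S)NNC(=O)CSCc1nc2cc([N+](=O)[O-])ccc2[nH]1` has not yet been measured. It differs from compound 2 on a carbonyl carbon: a group of 5 heavy atoms (1 carbon, 3 nitrogen, 1 sulfur; no ring) in place of a group of 7 heavy atoms (6 carbon, 1 chlorine; one six-membered aromatic ring of carbon only), on a carbonyl carbon. The 4-chlorophenyl group leaves, and a group with no common name and no ring enters. The closest guide is compound 3 (27400 nM), which also has no ring outside the shared core. Three compounds are thin evidence, so only a moderate move toward weaker inhibition is expected in this assay. The estimated change is a 2.5-fold higher number from compound 2 to compound 4 (0.40 log units; beyond the scatter), which is smaller than the gap seen for compound 3. Compound 4 is expected to give about 7000 nM, with an estimated range from 2000 nM to 25000 nM.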

Compound 4, half-maximal inhibitory concentration: 7530 nM
The estimate for compound 4 lay 1.1-fold (0.03 log units) below the measured number; the measured number falls inside the stated range.
By their numbers in this assay, from the lowest: compounds 1 and 2 (each within the scatter of the next); then compound 4; then compound 3.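

In this assay, replacing the 4-chlorophenyl group on the carbonyl carbon with a ringless group costs only a modest amount: the change is a 2.7-fold higher number from compound 2 to compound 4 (0.43 log units; beyond the scatter) and stays well short of the gap to compound 3. Compound 3 also has no ring outside the shared core, yet the data show a 3.6-fold lower number from compound 3 to compound 4 (0.56 log units; beyond the scatter) in favour of the larger ringless group of compound 4, so losing the ring does not by itself set the number at this position. No measurement shown here explains either step.

Going by these compounds, it remains open whether a plain phenyl ring, without the chlorine, would keep the number of compound 2. On these data alone, it is equally open whether a simple amine or a carboxylic acid on the carbonyl carbon would behave like the group in compound 4.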